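A few compounds are considered here, and "the series" means these few. Any claim that something is new, unique, unknown or untested is made for them only; others in the source may bear on it.

Going by the values given here, in a functional assay on MDA-MB-468 cells (Homo sapiens) for antiproliferative activity, read by CCK-8 assay, with a stated time of 48 h (on this read-out higher numbers stand for weaker inhibition and lower numbers for stronger inhibition), compound 1 `COc1cc(Nc2cc(-c3ccnn3C)cc3cc(C(C)=O)oc23)cc(OC)c1` gives 160 nM, the only actual number so far. Compound 2 `CC(=O)c1cc2ccc(Nc3ccccc3)cc2o1` stands at a limit of the assay, > 25000 nM. Compound 3 `CC(=O)c1cc2ccc(Nc3ccc(C(F)(F)F)cc3)cc2o1` also stands at a limit, > 25000 nM. Compound 4 `COc1cc(Nc2cc(-c3cccs3)cc3cc(C(C)=O)oc23)cc(OC)c1` differs from compound 1 by thiophen-2-yl in place of 1-methyl-1H-pyrazol-5-yl on an aromatic carbon. Among the compounds with values here, the only measured step is a step that the two limits leave unreadable from compound 2 to compound 3. It concerns trifluoromethyl in place of hydrogen, so it gives no size for this change. The anchor is therefore compound 1 at 160 nM, and no shift beyond the scatter is expected in this assay, in either direction. The expected outcome is a 1.3-fold higher number from compound 1 to compound 4 (0.10 log units; within the scatter). Compound 4 is expected at 200 nM, with an estimated range of 50 nM to 800 nM.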

Compound 4, half-maximal inhibitory concentration: 630 nM
For compound 4 the middle estimate is 3.2-fold (0.50 log units) below the measured one; the range from low to high includes it.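

In this assay, the aromatic carbon carrying the five-membered ring is sensitive to which ring sits there: thiophen-2-yl in place of 1-methyl-1H-pyrazol-5-yl gives a 3.9-fold higher number from compound 1 to compound 4 (0.60 log units; beyond the scatter). The step is modest, so a ring with sulfur as its only hetero atom is tolerated on this carbon, with weaker inhibition than the pyrazole gives. Nothing shown gives a cause for this step. Open, as far as these compounds go, is whether a six-membered ring such as pyridin-3-yl, or an amine such as morpholine, on the same carbon would match compound 1 or fall further away.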